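From 4-Fluorophenyl to 3,4-Dichlorophenyl: One Change, One Estimate

The source may hold more compounds than are shown below. What is called first, only, known or untested is meant among the compounds shown, and "the series" means these compounds.

- Compound 1 `CN1C/C(=C\c2ccc(C(C)(C)C)cc2)C(=O)/C(=C/c2ccccc2F)C1`: 9120 nM
- Compound 2 `CN1C/C(=C\c2ccc(F)cc2)C(=O)/C(=C/c2cccc([N+](=O)[O-])c2)C1`: 9340 nM

Both compounds were tested in a functional assay on HepG2 cells (Homo sapiens) for cytotoxicity, read by MTT assay, with a stated time of 24 h; on this read-out higher numbers stand for weaker inhibition and lower numbers for stronger inhibition. Compound 2 gives 9340 nM, which cannot be told apart from compound 1 at 9120 nM, as the two values lie within the usual scatter of repeated measurements.

The next compound to be tested is compound 3 `CN1C/C(=C\c2cccc([N+](=O)[O-])c2)C(=O)/C(=C/c2ccc(Cl)c(Cl)c2)C1`, which differs from compound 2 in one place: 3,4-dichlorophenyl in place of 4-fluorophenyl on a double-bonded chain carbon bound to a double-bonded ring carbon. Here 3,4-dichlorophenyl stands in place of 4-fluorophenyl on a double-bonded chain carbon bound to a double-bonded ring carbon.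

Among the compounds with values here, no measured pair differs in one place only, so the data show no direct precedent for this swap. The two values do show that compound 1 at 9120 nM and compound 2 at 9340 nM share the same range despite their different groups. Only a small move toward a lower number is therefore expected in this assay, perhaps none beyond the scatter. The expected step is a 1.3-fold lower number from compound 2 to compound 3 (0.13 log units; within the scatter).

For compound 3 the estimated value is 7000 nM, with an expected range of 3000 nM to 16000 nM.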

Compound 3, half-maximal inhibitory concentration: 5960 nM
Estimate against measurement, compound 3: 1.2-fold (0.07 log units) above, within the range that was stated.
By their numbers in this assay, from the lowest: compounds 3, 1 and 2 (each within the scatter of the next).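

Within the data shown here, this is the first pair here that differs in one place only, so a single change at this position can now be read directly. In this assay, 3,4-dichlorophenyl in place of 4-fluorophenyl on a double-bonded chain carbon bound to a double-bonded ring carbon gives a 1.6-fold lower number from compound 2 to compound 3 (0.20 log units; within the scatter), so this exchange of one halogen-bearing phenyl ring for another cannot be told apart from no change at all. Nothing available explains why the two groups read alike, and no further measurement bears on this result.

As far as these compounds go, it remains open whether the position would stay this undemanding with a group of another kind, such as a phenyl ring carrying an amine or a carboxylic acid, or a longer chain in place of the ring. Among these compounds, it is also open whether the same exchange would read alike if the rest of the molecule were different, since this single pair shares one background and gives only one step.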